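A few compounds are considered here, and "the series" means these few. Any claim that something is new, unique, unknown or untested is made for them only; others in the source may bear on it.

Measured compounds:
compound 1, `NS(=O)(=O)NC[C@H]1CC[C@H](C(=O)/C(=N/O)Nc2ccc(F)c(Br)c2)CC1`: in an assay for inhibition of Tryptophan 2,3-dioxygenase (Homo sapiens), with a stated time of 1 h (on this read-out higher numbers stand for weaker inhibition and lower numbers for stronger inhibition), compound 1 gives 58700 nM.
compound 2, `O=C(Nc1ccccc1)[C@H]1CC[C@H](C(=O)/C(=N/O)Nc2ccc(F)c(Br)c2)CC1`: in this assay compound 2 gives > 100000 nM, which is a limit of the assay rather than a number.
compound 3, `O=C(/C(=N/O)Nc1ccc(F)c(Br)c1)C1CCN(C(=O)c2ccccc2)CC1`: in this assay compound 3 gives > 100000 nM, likewise a limit.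

Compound 2 therefore stands at the limit of > 100000 nM in this assay, at which 2 of the 3 values shown sit. Compound 4, `O=C(/C(=N/O)Nc1ccc(F)c(Br)c1)C1CCCCC1`, differs from compound 2 by hydrogen in place of phenylcarbamoyl on a saturated ring carbon. Among the compounds with values here, the only measured step at this part of the shared core is an at least 1.7-fold higher number from compound 1 to compound 2 (0.23 log units; that floor lies within the scatter), and since it ends at a limit its true size stays open. Within the data shown here, no measured step shows what a bare hydrogen at this place does, so the expectation rests only on the weak inhibition seen so far. Compound 4 is expected near 70000 nM, with a range from 15000 nM to 300000 nM. This estimate means a step of an at least 1.4-fold lower number from compound 2 to compound 4 (0.15 log units; that floor lies within the scatter), which need not exceed the scatter.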

Compound 4, half-maximal inhibitory concentration: 79300 nM
Estimate against measurement, compound 4: 1.1-fold (0.05 log units) below; the measured number falls inside the stated range.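

Taking the substituent off this saturated ring carbon gives the first reading for a bare hydrogen there: in this assay the change gives an at least 1.2-fold lower number from compound 2 to compound 4 (0.10 log units; that floor lies within the scatter). Against the sulfamoyl-bearing side chain, it gives a 1.4-fold higher number from compound 1 to compound 4 (0.13 log units; within the scatter), so (sulfamoylamino)methyl shows no gain over hydrogen beyond the scatter. Compound 2 remains a limit rather than a number: the limit of > 100000 nM in this assay, at which 2 of the 4 values shown sit.

As far as these compounds go, the true size of the step from phenylcarbamoyl to hydrogen stays open. So does whether an amine or a carboxylic acid at this place would give stronger inhibition.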